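Benzohydrazone series: fluoro on the benzoyl ring

A few compounds are considered here, and "the series" means these few. Any claim that something is new, unique, unknown or untested is made for them only; others in the source may bear on it.

Going by the values given here, compound 1 `CCCCc1ccc2[nH]c(-c3ccc(OC)cc3)c(/C=N/NC(=O)c3ccccc3)c2c1` gives 130 nM in a functional assay on MCF7 cells (Homo sapiens) for antiproliferative activity, with a stated time of 5 days (a higher number here means a weaker inhibitor, a lower number a stronger inhibitor), the lowest of the two numbers measured so far. Its nearest neighbour is compound 2 `CCCCc1ccc2[nH]c(-c3ccc(C(F)(F)F)cc3)c(/C=N/NC(=O)c3ccccc3)c2c1`, which gives 460 nM in this assay; the step of a 3.5-fold higher number from compound 1 to compound 2 (0.55 log units; beyond the scatter) comes from trifluoromethyl in place of methoxy on an aromatic carbon of the aryl group attached to the shared core.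

Compound 3 `CCCCc1ccc2[nH]c(-c3ccc(OC)cc3)c(/C=N/NC(=O)c3ccc(F)cc3)c2c1` has not been measured. It differs from compound 1 by fluoro in place of hydrogen on an aromatic carbon. Among the compounds with values here, the change sits on the benzoyl ring of the hydrazone, a part of the molecule that no measured pair has varied. Within the data shown here, the single measured step of a 3.5-fold higher number from compound 1 to compound 2 (0.55 log units; beyond the scatter) concerns a different ring, so it bears on this change only indirectly, as a sign that one substituent on one aromatic carbon can move the number beyond the scatter. Without a step on the benzoyl ring itself, the expectation for compound 3 in this assay is a step of a 1.2-fold higher number from compound 1 to compound 3 (0.06 log units; within the scatter), not beyond the scatter in either direction. Compound 3 is estimated at 150 nM, within 60 nM to 400 nM.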

Compound 3, half-maximal inhibitory concentration: 84 nM
The estimate for compound 3 lay 1.8-fold (0.25 log units) above the measured number, and the stated range covers the measured number.
By their numbers in this assay, from the lowest: compounds 3 and 1 (each within the scatter of the next); then compound 2.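

The benzoyl ring of the hydrazone now has a measured step of its own: in this assay fluoro in place of hydrogen on an aromatic carbon, para to a large group, gives a 1.5-fold lower number from compound 1 to compound 3 (0.19 log units; within the scatter) and leaves compounds 1 and 3 indistinguishable in this read-out. Going by these compounds alone, this position therefore accepts one fluorine atom with no change beyond the scatter, unlike the only earlier step, a 3.5-fold higher number from compound 1 to compound 2 (0.55 log units; beyond the scatter) on the aryl group attached to the shared core, so a single substituent swap does not move the number beyond the scatter at every aromatic position. No measurement on hand gives a reason for either outcome.

The compounds shown carry only hydrogen or fluoro on the benzoyl ring, so they leave open whether a larger or ionisable group at the same place, such as a chloro, a dimethylamino or a carboxylic acid group, would keep the number within the scatter of compound 1. They also leave open whether the fluoro step would read the same with the trifluoromethyl group of compound 2 on the other aryl ring.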